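A few compounds are considered here, and "the series" means these few. Any claim that something is new, unique, unknown or untested is made for them only; others in the source may bear on it.

Measured in a functional assay on HT-29 cells (Homo sapiens) for inhibition, read by sulforhodamine B assay, with a stated time of 48 h; on this read-out lower numbers stand for stronger inhibition of growth and higher numbers for weaker inhibition of growth:
- compound 1 `CCOC(=O)c1nn(-c2ccc(Cl)cc2)c(-c2ccc([N+](=O)[O-])cc2)c1CNC(C)(C)C`: 42300 nM; 40800 nM (2 entries)
- compound 2 `Cc1ccc(-c2c(CNC(C)(C)C)c(C(=O)O)nn2-c2ccc(Cl)cc2)cc1`: > 629000 nM, a limit

Compound 2 stands on limits alone: the value shown for compound 2 is a limit, and a further entry for it also carries no single number.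

Compound 3 `CC(C)(C)NCc1c(C(=O)O)nn(-c2ccc(Cl)cc2)c1-c1ccc([N+](=O)[O-])cc1` follows from compound 2 by a single change, nitro in place of methyl on an aromatic carbon, para to a large group, that is 4-methylphenyl to 4-nitrophenyl (nitro in place of methyl on an aromatic carbon). Going by the values given here, no step between measured compounds is available to size this change in this assay. Nothing beyond the scatter is expected, in either direction, and the estimated step is an at least 1.1-fold lower number from compound 2 to compound 3 (0.05 log units; that floor lies within the scatter). This expectation rests only on compound 2 and its limit of > 629000 nM, so a report of a limit alone is also likely. Compound 3 is estimated at 550000 nM, with an expected range of 200000 nM to 900000 nM.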

Compound 3, concentration for 50% growth inhibition: > 583000 nM
Compound 3 gave a limit, no number; the forecaster's own chance of this, stated with the estimate: 70%; middle value at least 1.0-fold (0.02 log units) away from the limit.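

In this assay, compound 2 and compound 3 are each reported only as a limit, so no step can be read between them. The compounds shown leave open whether going from 4-methylphenyl to 4-nitrophenyl shifts growth inhibition at all, and in which direction.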